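Step from compound 2 to compound 3

The compounds below may be only part of what the source reports. "The series", "measured", "known", "first", "only" and "open" are said of these compounds alone.

Measured so far in a physicochemical assay for solubility, read by LC-MS, in phosphate buffer, with a stated time of 24 h, at pH 6.8; a lower number here means a less soluble compound, a higher number a more soluble compound:
compound 1 `C[C@H](NC(=O)c1ncccn1)c1ccc(NC(=O)N2CC(c3ccc(N)nc3)C2)cc1` gives 300000 nM
compound 2 `C[C@H](NC(=O)C1CCOCC1)c1ccc(NC(=O)N2CC(c3ccc(N)nc3)C2)cc1` gives 310000 nM

On these two numbers, compound 2 stands level with compound 1 within the scatter. Compound 3 `C[C@H](NC(=O)C1CCOCC1)c1ccc(NC(=O)N2CC(c3cncc(N)c3)C2)cc1` carries 5-aminopyridin-3-yl in place of 6-aminopyridin-3-yl on a saturated ring carbon of a four-membered non-aromatic ring with 1 nitrogen 5-aminopyridin-3-yl in place of 6-aminopyridin-3-yl on a saturated ring carbon with the same atoms joined differently. Going by the values given here, the only measured step is a 1.0-fold higher number from compound 1 to compound 2 (0.01 log units; within the scatter) and it lies within the scatter. That step concerns a group on a carbonyl carbon, so it bears only indirectly on this change. Among the compounds with values here, no measured step touches the group on the saturated ring carbon. No step beyond the scatter is therefore expected in this assay and no direction can be favoured. The estimated step is a 1.0-fold lower number from compound 2 to compound 3 (0.01 log units; within the scatter) with a wide margin. For compound 3 the expected value is 300000 nM within an estimated range from 130000 nM to 500000 nM.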

Compound 3, solubility: 440000 nM
Beside the measured number, compound 3's estimate is 1.5-fold (0.17 log units) below it; the measured number falls inside the stated range.
By their numbers in this assay, from the lowest: compounds 1, 2 and 3 (each within the scatter of the next).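

Going by these compounds alone, this is the first measured change on the saturated ring carbon of the four-membered non-aromatic ring with 1 nitrogen. In this assay, 5-aminopyridin-3-yl in place of 6-aminopyridin-3-yl gives a 1.4-fold higher number from compound 2 to compound 3 (0.15 log units; within the scatter), so with oxan-4-yl on the carbonyl carbon the two groups, which have the same atoms joined differently, cannot be told apart in this read-out. No available evidence bears on this result.

Still open is whether 5-aminopyridin-3-yl reads the same with pyrimidin-2-yl on the carbonyl carbon, a pairing absent from the compounds shown. Also open, from the compounds shown here alone, is how a different kind of group on the saturated ring carbon, such as a carboxylic acid or a morpholine, would stand in this assay against the two aminopyridinyl groups.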